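This account rests on a few compounds, and the source may have more. Where it says the series, first, only, none or still open, it means among the compounds named here.

Compound 1 `Nc1cc(=O)[nH]c(=O)n1[C@@H]1O[C@H](CO)[C@@H](O)[C@H]1O`: in a functional assay on LOX cells (Homo sapiens) for antiproliferative activity, read by WST assay, with a stated time of 3 days (on this read-out higher numbers stand for weaker inhibition and lower numbers for stronger inhibition), compound 1 gives > 50000 nM, which is a limit of the assay and not a number.
Compound 2 `COC(=O)c1cc(=O)[nH]c(=O)n1[C@@H]1O[C@H](CO)[C@@H](O)[C@H]1O`: in this assay compound 2 gives > 50000 nM, again a limit.
Compound 3 `O=Cc1cc(=O)[nH]c(=O)n1[C@@H]1O[C@H](CO)[C@@H](O)[C@H]1O`: in this assay compound 3 gives > 50000 nM, also a limit.

Compound 3 therefore stands nowhere in particular on a scale: its result, like that of the other two, is only a limit, and all three sit at the limit of > 50000 nM in this assay, at which 3 of the 3 values shown sit. The three steps that connect the measured compounds are a step that the two limits leave unreadable from compound 1 to compound 2, a step that the two limits leave unreadable from compound 1 to compound 3 and a step that the two limits leave unreadable from compound 2 to compound 3; none of them has a readable size.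

Compound 4 `O=Cc1c(F)c(=O)[nH]c(=O)n1[C@@H]1O[C@H](CO)[C@@H](O)[C@H]1O` is not yet measured. It differs from compound 3 by fluoro in place of hydrogen on an aromatic carbon. Going by the values given here, no measured step touches this position or this group, so nothing among the three compounds hints at a gain or loss. With every measured value at the limit, the expected step that the limit leaves unreadable from compound 3 to compound 4 is none that the numbers could show. Compound 4 is accordingly expected to give about 60000 nM in this assay, with a range from 15000 nM to 250000 nM.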

Compound 4, half-maximal inhibitory concentration: 400 nM
Beside the measured number, compound 4's estimate is 150-fold (2.18 log units) above it, and the stated range ends above it.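

Putting fluoro in place of hydrogen on this aromatic carbon, ortho to a formyl group, gives an at least 120-fold lower number from compound 3 to compound 4 (2.09 log units; beyond the scatter) in this assay. Going by these compounds alone, the steps among compound 1, compound 2 and compound 3 cannot be read, so this position is the first place where a change has a readable size. Compound 4 is also the only compound here with a value that is not a limit: the limit of > 50000 nM in this assay, at which 3 of the 4 values shown sit.

As far as these compounds go, whether the gain depends on the formyl group stays open, as fluoro appears here only on the formyl compound and not on the amino or methoxycarbonyl compounds. Also open, from the compounds shown here alone, is what another atom or group at this position, such as chlorine, a methyl group or an amine, would give.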